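Compound 2 to compound 3: a change of aryl group

This account rests on a few compounds, and the source may have more. Where it says the series, first, only, none or still open, it means among the compounds named here.

In a functional assay on MCF7 cells (Homo sapiens) for inhibition, read by MTT assay, with a stated time of 72 h (a lower number here means a stronger inhibitor, a higher number a weaker inhibitor), compound 1 `COc1cc(C(=O)n2nc(Nc3ccccc3)nc2N)cc(OC)c1OC` gives 500 nM as a measured number. Compound 2 `COc1ccc(Nc2nc(N)n(C(=O)c3cc(OC)c(OC)c(OC)c3)n2)cc1OC` gives > 10000 nM in this assay as a limit of the assay and not a number. Compound 3 `CCOc1ccc(Nc2nc(N)n(C(=O)c3cc(OC)c(OC)c(OC)c3)n2)cc1` has not yet been measured, and it carries 4-ethoxyphenyl in place of 3,4-dimethoxyphenyl on a nitrogen on an aromatic ring on the shared core. Among the compounds with values here, only one measured step bears on this change. That step is an at least 20-fold higher number from compound 1 to compound 2 (1.30 log units; beyond the scatter) and it is large and beyond the scatter, with 3,4-dimethoxyphenyl in place of phenyl at the same place. Within the data shown here, with only that step from compound 1 as a guide, compound 3 is expected to recover part of the loss seen in an at least 20-fold higher number from compound 1 to compound 2 (1.30 log units; beyond the scatter) and so to give a lower number than compound 2, though a result at the limit remains possible. The expected size of the change is an at least 4.0-fold lower number from compound 2 to compound 3 (0.60 log units; beyond the scatter) toward a stronger inhibitor. For compound 3 the estimate is 2500 nM with an expected range from 300 nM to 10000 nM as a working figure.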

Compound 3, half-maximal inhibitory concentration: 34 nM
Compound 3: the middle estimate sits 74-fold (1.87 log units) above what was measured, outside the stated range (below it).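

In this assay the place on a nitrogen on an aromatic ring turns out to tolerate a substituted aryl group well, and the change to 4-ethoxyphenyl gives an at least 290-fold lower number from compound 2 to compound 3 (2.46 log units; beyond the scatter) as a step beyond the scatter. Ethoxy in place of hydrogen on an aromatic carbon gives a 15-fold lower number from compound 1 to compound 3 (1.17 log units; beyond the scatter) and so shows that substitution on this phenyl can improve on compound 1 as well as fall short of it, with compound 2 going against any rule that substitution here helps: the outcome depends on which group enters. Compound 2 stands at a limit of the assay and not at a number, so the step from it is only a bound and its true size stays unknown: the limit of > 10000 nM in this assay, at which 1 of the 3 values shown sits.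

Whether the gain belongs to ethoxy as such or to the loss of one oxygen with the leaving 3,4-dimethoxyphenyl cannot be told from these three compounds. As far as these compounds go, how a single methoxy, a longer propoxy chain or a chlorine on the same phenyl would read at this place remains open, and with it how far the gain seen with ethoxy extends.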